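The compounds below may be only part of what the source reports. "The series", "measured", "known", "first", "only" and "open" are said of these compounds alone.

In an ADME assay on MT4 cells (Homo sapiens) for cytotoxicity, read by MTT assay, with a stated time of 4 days (a higher number here means that more compound is tolerated, a lower number that less compound is tolerated), compound 2 `Cc1cc(C)cc(C(=O)c2cc(Cl)ccc2OCCn2ccc(=O)[nH]c2=O)c1` gives > 313000 nM, which is a limit of the assay and not a number. Compound 1 `Cc1cc(C)cc(C(=O)c2cc(Cl)ccc2OCCn2cc(C)c(=O)[nH]c2=O)c1`, which carries one more methyl, gives > 303000 nM, also a limit. Compound 2 therefore has no measured number to start from. Compound 3 `Cc1cc(C)cc(C(=O)c2cc(Cl)ccc2OCCn2c(C)cc(=O)[nH]c2=O)c1` differs from compound 2 by methyl in place of hydrogen on an aromatic carbon, next to the ring nitrogen: methyl in place of hydrogen on an aromatic carbon. Among the compounds with values here, the one measured step that bears on this change is a step that the two limits leave unreadable from compound 1 to compound 2, where hydrogen takes the place of methyl on an aromatic carbon. Its size cannot be read, so it offers no size or direction to carry over. No step beyond the usual scatter is expected in this assay, and compound 3 may also be reported only as a limit. The expected change is an at least 1.1-fold lower number from compound 2 to compound 3 (0.04 log units; that floor lies within the scatter). Compound 3 is expected near 280000 nM, with an estimated range of 100000 nM to 320000 nM.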

Compound 3, half-maximal cytotoxic concentration: > 303000 nM
Compound 3: a limit, no number; the forecaster's own chance of this, stated with the estimate: 80%; middle value at least 1.0-fold (0.03 log units) from the limit.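

No new step can be read: compound 1, compound 2 and compound 3 are all reported as limits and not as numbers, which leaves every step among them unreadable. The compounds shown leave open whether methyl in place of hydrogen on an aromatic carbon changes the tolerated concentration at all.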